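The source may hold more compounds than are shown below. What is called first, only, known or untested is meant among the compounds shown, and "the series" means these compounds.

Of the compounds shown here, three built on one shared core have been tested in a physicochemical assay for solubility, using the shake flask method, in phosphate buffer, measured as kinetic solubility, with a stated time of 20 h, at pH 6.5; a lower number here means a less soluble compound, a higher number a more soluble compound. Compound 1 `FC(F)(F)c1cccc(-c2nc3cnc(Nc4ccccn4)cc3[nH]2)c1` gives < 5000 nM, a limit of the assay and not a number. Compound 2 `Fc1ccc(-c2nc3cnc(Nc4ccccn4)cc3[nH]2)cc1F` gives < 5000 nM, again a limit. Compound 3 `FC(F)(F)c1ccc(Nc2cc3[nH]c(-c4cccc(C(F)(F)F)c4)nc3cn2)nc1` gives < 5000 nM, also a limit, so it has no exact place on the scale. All the evidence so far comes down to the limit of < 5000 nM in this assay, at which 3 of the 3 values shown sit.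

The next compound, compound 4 `Fc1ccc(-c2nc3cnc(Nc4ccc(C(F)(F)F)cn4)cc3[nH]2)cc1F`, has 3,4-difluorophenyl in place of 3-(trifluoromethyl)phenyl on an aromatic carbon, between two ring nitrogen atoms: 3,4-difluorophenyl in place of 3-(trifluoromethyl)phenyl on an aromatic carbon. Within the data shown here, the one measured step that can be set beside this change is a step that the two limits leave unreadable from compound 1 to compound 3, where trifluoromethyl replaces hydrogen on an aromatic carbon. That step has no readable size and is a different change, so it gives no direction. The change expected in this assay is therefore none beyond the scatter, and the estimated step is a step that the limit leaves unreadable from compound 3 to compound 4. Compound 4 is expected at 2500 nM, with an estimated range of 800 nM to 5000 nM.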

Compound 4, solubility: < 5000 nM
Compound 4 gave a limit, no number (the forecaster's own chance of this, stated with the estimate: 85%); the middle value lies beyond the limit too.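

Compound 4, like compound 2 and compound 3, gives a limit and not a number in this assay, so its steps from those two compounds cannot be read: the limit of < 5000 nM in this assay, at which 4 of the 4 values shown sit. The compounds shown leave open how soluble each one actually is, and whether any of these changes shifts solubility at all.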